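The compounds below may be only part of what the source reports. "The series", "measured", "known", "first", "only" and "open" are said of these compounds alone.

Working notes on a series sharing one core. Compound 1 `CC(C)(C)NC(=O)N1CCN(C(=S)SCc2cn(Cc3ccccc3F)nn2)CC1` gives 40700 nM in a functional assay on MGC-803 cells (Homo sapiens) for cytotoxicity, read by MTT assay, with a stated time of 72 h (on this read-out lower numbers stand for stronger inhibition and higher numbers for weaker inhibition), compound 2 `O=C(NC1CCCCC1)N1CCN(C(=S)SCc2cn(Cc3ccccc3F)nn2)CC1` gives 36500 nM and compound 3 `O=C(NCc1ccccc1)N1CCN(C(=S)SCc2cn(Cc3ccccc3F)nn2)CC1` gives 13300 nM. Compound 2 thus sits second highest of the three numbers, with one step within the scatter (a 1.1-fold lower number from compound 1 to compound 2 (0.05 log units; within the scatter)) and one beyond it (a 2.7-fold lower number from compound 2 to compound 3 (0.44 log units; beyond the scatter)); the move from compound 1 to compound 3 was a 3.1-fold lower number from compound 1 to compound 3 (0.49 log units; beyond the scatter). All three measured steps alter the group on the amide-type nitrogen, which compound 4 `O=C(NC1CCCCC1)N1CCN(C(=S)SCc2cn(Cc3ccc(F)cc3)nn2)CC1` keeps; compound 4 differs from compound 2 by 4-fluorophenyl in place of 2-fluorophenyl on a saturated chain carbon bound to an aromatic nitrogen. Among the compounds with values here, no measured step touches the fluorophenyl, so nothing here bears directly on this change, and no step beyond the scatter is expected: no change at the digits printed from compound 2 to compound 4 (within the scatter). Compound 4 is therefore estimated at 36500 nM, within 18000 nM to 73000 nM.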

Compound 4, half-maximal inhibitory concentration: > 128000 nM
Compound 4 gave a limit, no number; the forecaster's own chance of this, stated with the estimate: 5%; middle value at least 3.5-fold (0.54 log units) away from the limit.
By their numbers in this assay, from the lowest: compound 3; then compounds 2 and 1 (each within the scatter of the next). At a limit, above all of these: compound 4.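

With cyclohexyl held on the amide-type nitrogen, 2-fluorobenzyl to 4-fluorobenzyl gives an at least 3.5-fold higher number from compound 2 to compound 4 (0.54 log units; beyond the scatter), the first step shown away from that nitrogen. Within the data shown here, the earlier compounds varied only the amide-type nitrogen group, so this is the first sign that the read-out in this assay responds to the fluorophenyl, though the same atoms are present in both compounds. Compound 4 gives a limit and no number: the limit of > 128000 nM in this assay, at which 1 of the 4 values shown sits.

The size of the step therefore has no upper bound. From the compounds shown here alone, whether the change holds with benzyl on the amide-type nitrogen stays open, as does the effect of a chlorobenzyl or a pyridinylmethyl at this place.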